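The source may hold more compounds than are shown below. What is called first, only, known or untested is meant among the compounds shown, and "the series" means these compounds.

Going by the values given here, in a functional assay on HT-1080 cells (Homo sapiens) for antiproliferative activity, read by MTT assay, with a stated time of 72 h (a lower number here means a stronger inhibitor, a higher number a weaker inhibitor), three compounds built on the shared core have numbers so far. Compound 1 (`COc1ccc(-c2ssc(=S)c2-c2cc(OC)c(OC)c(OC)c2)cc1`) gives 18600 nM, compound 2 (`COc1ccc(-c2ss/c(=N/O)c2-c2cc(OC)c(OC)c(OC)c2)cc1`) gives 6660 nM, and compound 3 (`COc1ccc(-c2ss/c(=N/O)c2-c2cc(OC)c(OC)c(OC)c2)cc1N`) gives 9360 nM. Compound 3 lies within the scatter of both of the others. Compound 4 (`CO/N=c1/ssc(-c2ccc(OC)c(N)c2)c1-c1cc(OC)c(OC)c(OC)c1`) differs from compound 3 by methyl in place of hydrogen on an oxygen, which turns hydroxy to methoxy. Among the compounds with values here, the only measured step, a 1.4-fold higher number from compound 2 to compound 3 (0.15 log units; within the scatter), is a different change, amino in place of hydrogen on an aromatic carbon, and no measured step touches this oxygen. Nothing beyond the scatter is therefore expected in this assay, in either direction. The expected step is a 1.2-fold lower number from compound 3 to compound 4 (0.07 log units; within the scatter). For compound 4 the estimated value is 8000 nM, with an expected range of 2500 nM to 27000 nM.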

Compound 4, half-maximal inhibitory concentration: 4230 nM
The estimate for compound 4 lay 1.9-fold (0.28 log units) above the measured number; the range from low to high includes it.
By their numbers in this assay, from the lowest: compounds 4, 2, 3 and 1 (each within the scatter of the next, the first and the last beyond it).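

In this assay, going by these compounds alone, methyl in place of hydrogen on the oxygen gives a 2.2-fold lower number from compound 3 to compound 4 (0.34 log units; beyond the scatter) and is the first change at this oxygen to be read. Unlike the only earlier step, which lay on an aromatic carbon and stayed within the scatter, this one is beyond it, though modest. Nothing measured here speaks to the reason for this step.

The compounds shown leave open whether an ethyl group or a longer chain on this oxygen would move the number further. They also leave open whether methoxy would give a similar step in compound 2, which lacks the amino group.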